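Methylating a Ring Nitrogen on Two Different Cores

The source may report more compounds than this note shows. Statements on the series, on what has been measured and on what is new or still open speak of the compounds shown alone.

Compound 2 `O=C(/C=C/c1cc(Br)c(Br)[nH]1)c1ccccc1O` and compound 1 `Cn1c(/C=C/C(=O)c2ccccc2O)cc(Br)c1Br` share one core and differ only at a ring nitrogen. In a functional assay on MCF7 cells (Homo sapiens) for cytotoxicity, read by MTT assay, with stated times of 6 h and 48 h (on this read-out lower numbers stand for stronger inhibition and higher numbers for weaker inhibition), compound 2 gives 1490 nM. In this assay compound 1 gives 2510 nM. The step between them is a 1.7-fold higher number from compound 2 to compound 1 (0.23 log units; within the scatter), and the change that made it is methyl in place of hydrogen on an aromatic nitrogen.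

Compound 3 `O=c1cc(-c2cc(Br)c(Br)[nH]2)oc2ccccc12` carries the same brominated five-membered ring on a second core; how the two cores differ is not broken down here. In this assay compound 3 reaches only a limit of the assay, >= 100000 nM. Going by the values given here, the one piece of evidence on the measured values is the limit of >= 100000 nM in this assay, at which 1 of the 3 values shown sits.

Compound 4 `Cn1c(-c2cc(=O)c3ccccc3o2)cc(Br)c1Br` is the counterpart of compound 3 on this second core, and it has not yet been measured. It differs from compound 3 by methyl in place of hydrogen on an aromatic nitrogen, the same change as that from compound 2 to compound 1, at the same place in the ring. That earlier step was within the scatter. Compound 3 itself sits at a limit, so the step that compound 4 would make cannot be read as a number either way. Compound 4 is therefore expected to give about 100000 nM in this assay, most likely again as a limit. The expected step is a number no higher from compound 3 to compound 4 (the limit leaves the size open). The expected range for compound 4 runs from 30000 nM to 300000 nM.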

Compound 4, half-maximal inhibitory concentration: >= 100000 nM
Compound 4 was reported as a limit; the forecaster's own chance of this, stated with the estimate: 70%; the middle value lies on the limit itself.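

In this assay compound 4 is reported only as a limit, as compound 3 was, so no step can be read between compound 3 and compound 4. The compounds shown leave open where the true values of compound 3 and compound 4 lie, and whether methyl in place of hydrogen on the aromatic nitrogen changes the number at all on this core. The values shown share one feature: the limit of >= 100000 nM in this assay, at which 2 of the 4 values shown sit.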